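A few compounds are considered here, and "the series" means these few. Any claim that something is new, unique, unknown or untested is made for them only; others in the source may bear on it.

Compound 1, `CCCCCCCON1C(=O)[C@@H](NC(=O)OCCCCC2CCCCC2)[C@@H]1C` — 2230 nM
Compound 2, `CSCCCON1C(=O)[C@@H](NC(=O)OCCCCC2CCCCC2)[C@@H]1C` — 167 nM
Compound 3, `C[C@H]1[C@H](NC(=O)OCCCCC2CCCCC2)C(=O)N1OCCCS(C)(=O)=O` — 49 nM

All three compounds share the same core and differ only in the group at the end of one side chain. Compound 3 gives the lowest number of the three in an assay on HEK293 cells for inhibition of N-acylethanolamine-hydrolyzing acid amidase (Homo sapiens), read by fluorescence, with stated times of 10 min and 50 min; on this read-out higher numbers stand for weaker inhibition and lower numbers for stronger inhibition; its step from compound 2 is a 3.4-fold lower number from compound 2 to compound 3 (0.53 log units; beyond the scatter) and its step from compound 1 is a 46-fold lower number from compound 1 to compound 3 (1.66 log units; beyond the scatter), both beyond the scatter, so compound 3 is the strongest inhibitor among those measured. Compound 4, `CC(=O)CCCON1C(=O)[C@@H](NC(=O)OCCCCC2CCCCC2)[C@@H]1C`, has not yet been measured. The change from compound 3 is acetyl in place of methylsulfonyl on a saturated chain carbon, three bonds along the chain from an oxygen. Going by the values given here, no measured step exchanges a methylsulfonyl for an acetyl. Among the compounds with values here, the steps that come closest are a 13-fold lower number from compound 1 to compound 2 (1.13 log units; beyond the scatter) and a 3.4-fold lower number from compound 2 to compound 3 (0.53 log units; beyond the scatter), which show that the group at this position moves the number over a wide span and that methylsulfonyl gave the lowest number so far. As far as these compounds go, since acetyl is untested, compound 4 is expected to give a number somewhat higher than compound 3. The expected step is a 1.8-fold higher number from compound 3 to compound 4 (0.26 log units; within the scatter). The estimate for compound 4 in this assay is 90 nM, with a range from 30 nM to 270 nM.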

Compound 4, half-maximal inhibitory concentration: 75 nM
For compound 4 the middle estimate is 1.2-fold (0.08 log units) above the measured one, and the stated range covers the measured number.
By their numbers in this assay, from the lowest: compounds 3 and 4 (each within the scatter of the next); then compound 2; then compound 1.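

In this assay, swapping methylsulfonyl for acetyl leaves the number essentially unchanged, a 1.5-fold higher number from compound 3 to compound 4 (0.18 log units; within the scatter), so the two groups cannot be told apart at this position and sulfur is not required for a number in this range. Acetyl also clearly improves on the other two groups, with a 2.2-fold lower number from compound 2 to compound 4 (0.35 log units; beyond the scatter) and a 30-fold lower number from compound 1 to compound 4 (1.47 log units; beyond the scatter), so a sulfur-free group can outdo methylsulfanyl and far outdo the butyl-ended chain of compound 1. The data offer no measured explanation for why acetyl and methylsulfonyl perform alike.

The compounds shown leave open whether an amide, a carboxylic acid or a hydroxyl group at the same place would also stay in this range. They also leave open whether acetyl would hold its number on a longer chain.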